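Mirror-Image Pair at Two Ring Stereocentres

A few compounds are considered here, and "the series" means these few. Any claim that something is new, unique, unknown or untested is made for them only; others in the source may bear on it.

Measured so far:
compound 1, `COC(=O)[C@@H]1c2cc(/C=C/C(=O)NCCCCNC(=N)N)ccc2O[C@H]1c1ccc(O)cc1`, 9720000 nM
compound 2, `N=C(N)NCCCCNC(=O)/C=C/c1ccc(O)cc1`, > 100000000 nM

In a functional assay on Caudal artery for antagonist activity at Alpha-1A adrenergic receptor (Rattus norvegicus) (a lower number here means a stronger inhibitor, a higher number a weaker inhibitor), compound 1 gives 9720000 nM. Compound 2 yields no number in this assay; its entry > 100000000 nM is a limit of the assay, (the limit of > 100000000 nM in this assay, at which 1 of the 2 values shown sits). Compound 1 therefore stands as the holder of the only actual number shown, the other entry being that limit, and its potency in this assay is very weak.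

Compound 3, `COC(=O)[C@H]1c2cc(/C=C/C(=O)NCCCCNC(=N)N)ccc2O[C@@H]1c1ccc(O)cc1`, has not yet been measured. Compared with compound 1 it changes only in configuration: the two compounds have the same atoms and bonds; at least one stereo element is drawn with a configuration in one of them and without one in the other: 2 of 4 stereo elements differ; a stereocentre at a saturated ring carbon is drawn R in compound 1 and S in compound 3; a stereocentre at a saturated ring carbon is drawn R in compound 1 and S in compound 3. No step between two measured compounds is shown, and no measured pair offers an anchor for the direction of such a change. The expectation is a step of no size beyond the scatter, with a wide range kept open in both directions. Compound 3 is expected to give about 15000000 nM in this assay, most likely between 3000000 nM and 100000000 nM. The expected step is a 1.5-fold higher number from compound 1 to compound 3 (0.19 log units; within the scatter).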

Compound 3, half-maximal inhibitory concentration: 42200000 nM
Compound 3: middle estimate off by 2.8-fold (0.45 log units), on the low side; the measured number falls inside the stated range.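

In this assay, the configuration at the two saturated ring carbons proves not to be silent: inverting both from R to S gives a 4.3-fold higher number from compound 1 to compound 3 (0.64 log units; beyond the scatter). Among these compounds, this is the first measured step on the shared core, and it gives the change a direction that was unknown before, with the form drawn R at both ring carbons, compound 1, the stronger of the pair, although the step is modest and compound 3 at 42200000 nM remains a very weak inhibitor. The step should be read with one reservation, which limits how firmly it can be tied to a clean exchange of configurations: the fact that one of compounds 1 and 3 is drawn with a defined configuration and the other without, at the place where they differ

On these data alone, the two stereocentres change together here, and which of them carries the step stays open, as does the result of changing only one of them. Also open, as far as these compounds go, is whether the same preference for compound 1 over compound 3 would hold with a carboxylic acid in place of the methyl ester, or with a longer chain leading to the guanidine.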